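One ring group exchanged on the shared core

The compounds below may be only part of what the source reports. "The series", "measured", "known", "first", "only" and "open" are said of these compounds alone.

In an ADME assay on Vero cells (Chlorocebus sabaeus) for cytotoxicity, read by MTT assay, with a stated time of 72 h (on this read-out higher numbers stand for weaker inhibition and lower numbers for stronger inhibition), compound 1 `CC1CN(c2nc3c(cc2[N+](=O)[O-])c(=O)c(C(=O)O)cn3-c2ccc(F)cc2)CC(C)O1` gives 141000 nM. For compound 2 `O=C(O)c1cn(-c2ccc(F)cc2)c2nc(N3CCC(N4CCCCC4)CC3)c([N+](=O)[O-])cc2c1=O` the result is only a limit, > 126000 nM. Among the compounds with values here, the one measured step, a step that the limit leaves unreadable from compound 1 to compound 2, therefore offers no size to carry over. Compound 3 `O=C(O)c1cn(-c2ccc(F)cc2)c2nc(N3CCC4(CC3)OCCO4)c([N+](=O)[O-])cc2c1=O` differs from compound 2 by a group of 10 heavy atoms (7 carbon, 1 nitrogen, 2 oxygen; one five-membered non-aromatic ring with 2 hetero atoms, one six-membered non-aromatic ring with 1 hetero atom) in place of a group of 12 heavy atoms (10 carbon, 2 nitrogen; 2 six-membered non-aromatic rings with 1 hetero atom each), on an aromatic carbon, ortho to a nitro group. Within the data shown here, with compound 1 at 141000 nM as the only number available, no change beyond the scatter is expected. The estimated step is a step that the limit leaves unreadable from compound 2 to compound 3. Compound 3 is expected at 130000 nM, with an estimated range of 60000 nM to 250000 nM.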

Compound 3, half-maximal inhibitory concentration: 133000 nM
Estimate against measurement, compound 3: 1.0-fold (0.01 log units) below; the range from low to high includes it.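

In this assay, placing the group of compound 3 in place of 2,6-dimethylmorpholin-4-yl on the aromatic carbon ortho to a nitro group gives a 1.1-fold lower number from compound 1 to compound 3 (0.03 log units; within the scatter). This gives the position its first readable step, and the two ring groups do not separate on this read-out. The value of compound 2 is a limit, and its steps to the other two compounds cannot be read: the limit of > 126000 nM in this assay, at which 1 of the 3 values shown sits.

Every group shown at this position is a ring joined through its nitrogen. From the compounds shown here alone, how an open-chain amine such as dimethylamino or a single chlorine atom would read there remains open.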